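Moving the Bromine Around the Benzyl Ring of a Triazole Chalcone

A few compounds are considered here, and "the series" means these few. Any claim that something is new, unique, unknown or untested is made for them only; others in the source may bear on it.

Of the compounds shown here, three sharing one core have been measured in a functional assay on MIA PaCa-2 cells (Homo sapiens) for inhibition, read by MTT assay, with a stated time of 48 h, tested at 10 uM; a higher number here means more inhibition of growth at the concentration tested, a lower number less inhibition of growth. Compound 1 `O=C(/C=C/c1ccc(OCc2cn(Cc3ccc(Br)cc3)nn2)cc1)c1ccc(Br)cc1` gives 29%. Compound 2 `COc1ccc(C(=O)/C=C/c2ccc(OCc3cn(Cc4ccccc4Br)nn3)cc2)cc1` gives 50%, and compound 3 `COc1ccc(C(=O)/C=C/c2ccc(OCc3cn(Cc4cccc(Br)c4)nn3)cc2)cc1` gives 50%. Among the compounds with values here, the one single-change step among them, no change at the digits printed from compound 2 to compound 3 (within the scatter), stayed within the scatter. Compound 3 thus stands level with compound 2 at the top of the three numbers, while compound 1, which differs from it in more than one place, lies a good way lower.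

Compound 4 `COc1ccc(C(=O)/C=C/c2ccc(OCc3cn(Cc4ccc(Br)cc4)nn3)cc2)cc1` is the next compound, and it differs from compound 3 by 4-bromophenyl in place of 3-bromophenyl on a saturated chain carbon bound to an aromatic nitrogen. Within the data shown here, the only step that bears on this, the move from compound 2 to compound 3, was flat, so a second move of the bromine around the same ring is expected to leave this assay within the scatter as well; a small downward drift is allowed, since compound 1, which carries the same 4-bromobenzyl group, sits low, though it also differs elsewhere. The estimated step is therefore a number 4 percentage points lower from compound 3 to compound 4 (within the scatter). Compound 4 is expected to give 46%, with a range from 32% to 60%.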

Compound 4, percent growth inhibition at one concentration: 56%
For compound 4 the middle estimate is 10 percentage points below the measured one; the range from low to high includes it.
By their numbers in this assay, from the lowest: compound 1; then compounds 2, 3 and 4 (each within the scatter of the next).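

With 4-bromophenyl in the series, three placements of the bromine can be compared on the shared core in this assay, and neither a number 6 percentage points higher from compound 3 to compound 4 (within the scatter) nor a number 6 percentage points higher from compound 2 to compound 4 (within the scatter) leaves the scatter, so the bromine's place on this ring shows no readable effect on the number. Within the data shown here, compound 4 also supplies the first single-change comparison for compound 1: a number 27 percentage points higher from compound 1 to compound 4 (beyond the scatter), with methoxy in place of bromo on an aromatic carbon, lies beyond the scatter, so the low number of compound 1 cannot be laid to the 4-bromobenzyl group that both carry. Nothing given here accounts for either finding.

Going by these compounds, it remains open whether an amine or a carboxylic acid in place of the bromine on the benzyl ring would shift the number. On these data alone, it also remains open whether the methoxy gain would hold with the 2-bromobenzyl or 3-bromobenzyl group.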